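Adding a Methyl to a Shared Core in Two Places

This account rests on a few compounds, and the source may have more. Where it says the series, first, only, none or still open, it means among the compounds named here.

Compound 1 `Cc1cccc(-c2cc(O)c3ccc(C)nc3n2)c1` gives 490 nM in a functional assay on OVCAR-3 cells (Homo sapiens) for antiproliferative activity; on this read-out higher numbers stand for weaker inhibition of growth and lower numbers for stronger inhibition of growth.
Compound 2 `Oc1cc(-c2ccc3ccccc3c2)nc2ncccc12` gives 8320 nM in this assay.
Compound 3 `Cc1cccc(-c2cc(O)c3c(C)cc(C)nc3n2)c1` gives 30200 nM in this assay.

Compound 1 and compound 2 carry different groups on the shared core; the difference between the two cores is not broken down here. Compound 3 differs from compound 1 by methyl in place of hydrogen on an aromatic carbon, and that step made a large difference: a 62-fold higher number from compound 1 to compound 3 (1.79 log units; beyond the scatter). Compound 2 stands between them, with the number of compound 1 well below it and that of compound 3 above it.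

Compound 4 `Cc1cnc2nc(-c3ccc4ccccc4c3)cc(O)c2c1` has not been measured yet. It differs from compound 2 by methyl in place of hydrogen on an aromatic carbon. Among the measured compounds shown here, this is the same kind of change as the one from compound 1 to compound 3, but not the same: in compound 3 the methyl sits ortho to a fused ring and opposite the ring nitrogen, whereas in compound 4 it sits two atoms from the ring nitrogen and para to a fused ring. Because of a 62-fold higher number from compound 1 to compound 3 (1.79 log units; beyond the scatter) the methyl is expected to weaken growth inhibition here too, though the different place makes the size of the step uncertain. For compound 4 the step is estimated as a 3.6-fold higher number from compound 2 to compound 4 (0.56 log units; beyond the scatter), and its value in this assay is estimated at 30000 nM, most likely between 6000 nM and 150000 nM.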

Compound 4, concentration for 50% growth inhibition: 355 nM
Compound 4: the middle estimate sits 85-fold (1.93 log units) above what was measured; the whole stated range lies above it.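

In this assay, putting a methyl in place of a hydrogen on an aromatic carbon gave a 23-fold lower number from compound 2 to compound 4 (1.37 log units; beyond the scatter), so growth inhibition became stronger, whereas the same kind of change made it weaker in the other pair of compounds. Within this series, then, knowing what a methyl did on one core did not predict even the direction of its effect on another, and the two results clearly differ: the same change on two cores in this assay, a 62-fold higher number (1.79 log units; beyond the scatter) from compound 1 to compound 3 and a 23-fold lower number (1.37 log units; beyond the scatter) from compound 2 to compound 4, 1400-fold (3.16 log units) apart, beyond the scatter of two such steps

What this does not show is why the two steps point in opposite directions, since the pairs differ both in the rest of the core and in where the methyl sits, and two steps cannot separate those two differences. In compound 4 the methyl lies two atoms from the ring nitrogen and para to a fused ring, and the compounds shown do not include a matching pair with the methyl at this same place on the core of compound 1, which would test the core on its own. On these data alone, it also remains open whether an ethyl, a methoxy or a chlorine at the place of the methyl in compound 4 would strengthen growth inhibition as the methyl does.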